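The source may hold more compounds than are shown below. What is called first, only, known or untested is meant among the compounds shown, and "the series" means these compounds.

Working notes on the series.

Of the compounds shown here, two of the shared core have been measured in a functional assay on the whole organism for inhibition, with Rattus norvegicus as the target, read by paw edema, at a dose of 100 mg/kg by the oral route; a lower number here means less inhibition, a higher number more inhibition at the dose given (going by the name of the read-out). Compound 1 `CN(C)CCNC(=O)c1c(O)c2cccnc2n(-c2ccccc2)c1=O` gives 22.6% in this assay. Among the compounds with values here, compound 2 `O=C(Nc1cccc([N+](=O)[O-])c1)c1c(O)c2cccnc2n(-c2ccccc2)c1=O` gives 5.7% in this assay, and the step of a number 16.9 percentage points lower from compound 1 to compound 2 (beyond the scatter) places compound 2 as the lower of the two numbers, with compound 1 as its only neighbour.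

Compound 3 `Cc1ccccc1NC(=O)c1c(O)c2cccnc2n(-c2ccccc2)c1=O` is the next compound to be measured. Relative to compound 2 the change is 2-methylphenyl in place of 3-nitrophenyl on an amide-type nitrogen. Within the data shown here, no measured step swaps one aryl group for another on the amide-type nitrogen; the single step in hand, from compound 1 to compound 2, replaces a 2-(dimethylamino)ethyl chain by 3-nitrophenyl and is only a loose guide here. It shows that the amide substituent can shift this read-out by a modest amount, but it does not say in which direction an aryl-to-aryl exchange would go. The expectation for compound 3 is therefore a step of a number 6.3 percentage points higher from compound 2 to compound 3 (within the scatter) in this assay, which is close to or slightly above the scatter.

Compound 3 is thus estimated at 12% in this assay, within a range from 0% to 30%.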

Compound 3, a percentage reported as inhibition, in the whole organism at one dose (the size of the read-out at that dose, not a potency): 11.7%
Compound 3: the middle estimate sits 0.3 percentage points above what was measured; the range from low to high includes it.
By their numbers in this assay, from the lowest: compounds 2 and 3 (each within the scatter of the next); then compound 1.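

In this assay, within the data shown here, the exchange of 3-nitrophenyl for 2-methylphenyl on the amide-type nitrogen is the first aryl-to-aryl comparison at this position, and it gives a number 6 percentage points higher from compound 2 to compound 3 (within the scatter) so these two aryl amides are not separated, although the leaving group carries 2 hydrogen-bond acceptors and the entering group carries none. Among these compounds, the 2-(dimethylamino)ethyl amide stands apart from this second aryl amide as well, with a number 10.9 percentage points lower from compound 1 to compound 3 (beyond the scatter) and so both aryl amides now lie beyond the scatter from compound 1, with no compound among the three going against this. Nothing measured bears on the origin of these differences.

From the compounds shown here alone, it remains open whether the higher number of compound 1 belongs to the terminal dimethylamino group or to the open chain itself, a question that a plain butyl chain, or a longer chain ending in a piperidine, on the same amide-type nitrogen would address. Going by these compounds, it is equally open whether any aryl group can move this read-out beyond the scatter, for example a 4-methoxyphenyl or a pyridyl ring in place of 2-methylphenyl.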